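Cyclopentyl on the Ring Nitrogen: An Expected Shift

A few compounds are considered here, and "the series" means these few. Any claim that something is new, unique, unknown or untested is made for them only; others in the source may bear on it.

Of the compounds shown here, three built on a shared core have been tested in a functional assay on HCT-116 cells (Homo sapiens) for cytotoxicity, read by sulforhodamine B assay, with a stated time of 72 h; on this read-out lower numbers stand for stronger inhibition and higher numbers for weaker inhibition. Compound 1 `FC(F)(F)c1ccc(N2CCN(c3ncnc4[nH]cnc34)CC2)cc1` gives 5100 nM in this assay. Compound 2 `Cc1ccc(S(=O)(=O)n2cnc3c(N4CCC(C)CC4)ncnc32)cc1` gives 14600 nM in this assay, and compound 3 `Cc1ccc(S(=O)(=O)n2cnc3c(NCc4ccc(Cl)cc4Cl)ncnc32)cc1` gives 28100 nM. Compound 1 therefore stands lowest of the three, and its gaps to compound 2 and to compound 3 both lie beyond the usual scatter of repeated measurements, so among these three it is the strongest inhibitor of cell growth.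

Compound 4 `FC(F)(F)c1ccc(N2CCN(c3ncnc4c3ncn4C3CCCC3)CC2)cc1` has not yet been measured. It differs from compound 1 in a single place: cyclopentyl in place of hydrogen on an aromatic nitrogen. Among the compounds with values here, no pair of measured compounds shows this change, so its effect can only be estimated. The expectation is a step in this assay toward a lower number, beyond the scatter but not a dramatic one, since nothing in the measured set argues for a large swing in either direction. Compound 4 is expected to give 2500 nM in this assay, with a likely range from 600 nM to 12000 nM. This estimate corresponds to an expected step of a 2.0-fold lower number from compound 1 to compound 4 (0.31 log units; beyond the scatter) in this assay.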

Compound 4, half-maximal inhibitory concentration: < 100 nM
Compound 4 was reported as a limit; the forecaster's own chance of this, stated with the estimate: 5%; at least 25-fold (1.39 log units) between middle value and limit.
By their numbers in this assay, from the lowest: compound 1; then compounds 2 and 3 (each within the scatter of the next). At a limit, below all of these: compound 4.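

Cyclopentyl in place of hydrogen on this aromatic nitrogen brings an at least 51-fold lower number from compound 1 to compound 4 (1.70 log units; beyond the scatter), so this position can strongly change the result, which no earlier pair could show. In this assay compound 4 is recorded as a limit, < 100 nM, not as an exact number, so the full size of the step remains unknown: the limit of < 100 nM in this assay, at which 1 of the 4 values shown sits.

The hydrogen on this nitrogen is therefore not needed for cytotoxicity in these cells, and replacing it with a carbon-only ring does not weaken the effect on this read-out.

From the compounds shown here alone, whether this gain is specific to cyclopentyl or would also come with other groups on the same nitrogen remains open. A small methyl, a longer chain such as hexyl, or a chain ending in an amine could give quite different results, and the compounds shown offer no guide to them.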